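Methyl for Trifluoromethyl on Two Related Cores

The source may report more compounds than this note shows. Statements on the series, on what has been measured and on what is new or still open speak of the compounds shown alone.

Compound 1 `O=C(CCCCCc1cccc(C(F)(F)F)c1)N1CCOC1=O` and compound 2 `Cc1cccc(CCCCCC(=O)N2CCOC2=O)c1` share one core, while compound 3 `O=C(CCCCCc1ccc(C(F)(F)F)cc1)N1CCOC1=O` and compound 4 `Cc1ccc(CCCCCC(=O)N2CCOC2=O)cc1` share another; the difference between the two cores is not broken down here. In an assay on HEK293 cells for inhibition of N-acylethanolamine-hydrolyzing acid amidase (Rattus norvegicus), read by LC-MS, with a stated time of 30 min (a lower number here means a stronger inhibitor, a higher number a weaker inhibitor), compound 1 gives 58 nM, compound 2 gives 350 nM, and compound 3 gives 1040 nM, the highest of the three numbers. From compound 1 to compound 2 the change is methyl in place of trifluoromethyl on an aromatic carbon, and it brought a 6.0-fold higher number from compound 1 to compound 2 (0.78 log units; beyond the scatter). From compound 3 to compound 4 the change is methyl in place of trifluoromethyl on an aromatic carbon. The group that leaves and the group that enters are the same in both pairs, but in the first the place is meta to a large group and in the second it is para to a large group, so this is the same kind of change rather than the same one. Because the measured pair gave a 6.0-fold higher number from compound 1 to compound 2 (0.78 log units; beyond the scatter), a step in the same direction is expected for compound 4, a 3.8-fold higher number from compound 3 to compound 4 (0.59 log units; beyond the scatter), though with wider uncertainty since the place differs. Compound 4 is therefore estimated at 4000 nM, expected to fall between 1500 nM and 12000 nM.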

Compound 4, half-maximal inhibitory concentration: 440 nM
For compound 4 the middle estimate is 9.1-fold (0.96 log units) above the measured one, and the stated range ends above it.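

In this assay, methyl in place of trifluoromethyl gave a 2.4-fold lower number from compound 3 to compound 4 (0.37 log units; beyond the scatter), so this step runs opposite to the one seen on the other core. Set side by side, the two steps show that this change did not carry over from one core to the other, in either direction or size: the same change on two cores in this assay, a 6.0-fold higher number (0.78 log units; beyond the scatter) from compound 1 to compound 2 and a 2.4-fold lower number (0.37 log units; beyond the scatter) from compound 3 to compound 4, 14-fold (1.15 log units) apart, beyond the scatter of two such steps. This means that, in this series, the result of the change on one core is a poor guide to its result on the other, but two pairs cannot show why the steps part or how the change would behave on a further core.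

Among the compounds shown, the aromatic ring carries only methyl or trifluoromethyl, so it remains open how a chlorine atom or a methoxy group would compare on either core. Also open, from the compounds shown here alone, is whether the two cores would still part in the same way with a shorter or longer chain.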